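The source may report more compounds than this note shows. Statements on the series, on what has been measured and on what is new or still open speak of the compounds shown alone.

Measured so far:
Compound 1, `Cc1ccc(C2=NN(C(N)=S)C(c3ccc(C)cc3)C2)cc1` — 6 nM
Compound 2, `Cc1ccc(C2=NN(C(N)=S)C(c3ccco3)C2)cc1` — 4 nM

In an assay on mitochondria for inhibition of Amine oxidase [flavin-containing] A (Bos taurus) (a higher number here means a weaker inhibitor, a lower number a stronger inhibitor), compound 1 gives 6 nM, the higher of the two numbers shown. Compound 2 gives 4 nM, and the step of a 1.5-fold lower number from compound 1 to compound 2 (0.18 log units; within the scatter) does not rise above the usual scatter, so the two values cannot be told apart. That step concerns the group on the saturated ring carbon of the shared core.

Compound 3, `Cc1ccc(C2CC(c3ccc(F)cc3)=NN2C(N)=S)cc1`, changes a different place: fluoro in place of methyl on an aromatic carbon. Going by the values given here, no measured step touches this aromatic ring, so the only guidance is indirect. Among the compounds with values here, the one step on record, from compound 1 to compound 2, swapped a whole aryl group elsewhere on the core without moving the number beyond the scatter, which gives no reason to expect a large shift from a single-atom exchange here.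

Compound 3 is therefore expected to give 7 nM, with a likely range from 3 nM to 18 nM. The expected step of a 1.2-fold higher number from compound 1 to compound 3 (0.07 log units; within the scatter) is estimated to stay within the scatter, in no clear direction.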

Compound 3, inhibition constant: 7 nM
For compound 3 middle estimate and measured number coincide at the digits printed; the measured number falls inside the stated range.
By their numbers in this assay, from the lowest: compounds 2, 1 and 3 (each within the scatter of the next).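

In this assay, going from 4-methylphenyl to 4-fluorophenyl gives a 1.2-fold higher number from compound 1 to compound 3 (0.07 log units; within the scatter), so methyl and fluoro cannot be told apart at this place. Going by these compounds alone, the earlier step changed only the group on the saturated ring carbon, so this is the only direct reading of the other 4-methylphenyl group, and it shows that exchanging one heavy atom there leaves no measurable difference. Nothing measured on these compounds offers an explanation for this result.

Methyl and fluoro are the only two groups shown at this place, so it remains open whether something quite different there, such as an amine, a carboxylic acid or a longer chain, would shift the number beyond the scatter. Within the data shown here, also open is whether fluoro in place of methyl would read the same with furan-2-yl on the saturated ring carbon, as in compound 2, since no pair of compounds shows that exchange on that background.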